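The compounds below may be only part of what the source reports. "The series", "measured", "known", "first", "only" and "open" are said of these compounds alone.

Measured so far in a toxicity assay on NIH3T3 cells (Mus musculus) for cytotoxicity, read by resazurin assay; on this read-out higher numbers stand for an effect only at larger amounts of compound and lower numbers for an effect already at smaller amounts:
- Compound 1 `COC(=O)c1ccc(NCc2cncn2Cc2cccc([N+](=O)[O-])c2)cc1-c1ccccc1`: > 10000 nM
- Compound 2 `COC(=O)c1ccc(NCc2cncn2Cc2ccccc2-c2ccccc2)cc1-c1ccccc1`: "not determined" (no result reported)
- Compound 3 `COC(=O)c1ccc(NCc2cncn2Cc2cccc(OC)c2)cc1-c1ccccc1`: "not determined" (no result reported)

Compound 3 has no single number, since its entry reads "not determined" (no result reported) and so gives it no place on the scale. The next compound is compound 4 `COC(=O)c1ccc(NCc2cncn2Cc2cccc(N)c2)cc1-c1ccccc1`, which has not been measured yet. The change amino in place of methoxy on an aromatic carbon puts amino in place of methoxy on an aromatic carbon, turning 3-methoxybenzyl into 3-aminobenzyl. Within the data shown here, no measured step shows what such a change does in this assay, so no shift beyond the scatter is expected, in either direction. This expectation leans only on compound 1, whose entry of > 10000 nM is a limit of the assay and not a number. For compound 4 the estimated value is 12000 nM in this assay, with an expected range from 3000 nM to 40000 nM and a fair chance of another limit.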

Compound 4, half-maximal effective concentration: > 10000 nM
Compound 4 gave a limit, no number; the forecaster's own chance of this, stated with the estimate: 65%; the middle value is on the limit's open side.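

Compound 1 and compound 4 each give a limit of the assay and not a number, so no step between them can be read: the limit of > 10000 nM in this assay, at which 2 of the 4 values shown sit.

The compounds shown leave open whether amino in place of nitro on an aromatic carbon changes the result in this assay at all.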